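A few compounds are considered here, and "the series" means these few. Any claim that something is new, unique, unknown or untested is made for them only; others in the source may bear on it.

Three measured compounds share one core and differ only in the group at one aromatic position. In a functional assay for inhibition of sodium/hydrogen exchanger (Oryctolagus cuniculus) (on this read-out higher numbers stand for weaker inhibition and lower numbers for stronger inhibition), compound 1, `Cc1cc(Br)c(S(C)(=O)=O)cc1C(=O)N=C(N)N`, gives 12 nM; compound 2, `Cc1cc(O)c(S(C)(=O)=O)cc1C(=O)N=C(N)N`, gives 220 nM; and compound 3, `COc1cc(C)c(C(=O)N=C(N)N)cc1S(C)(=O)=O`, gives 16 nM. Compound 3 thus stands second highest of the three numbers: the step of a 1.3-fold higher number from compound 1 to compound 3 (0.12 log units; within the scatter) stays within the scatter, while the step of a 14-fold lower number from compound 2 to compound 3 (1.14 log units; beyond the scatter) is large. Compound 4, `Cc1cc(OC(C)(C)C)c(S(C)(=O)=O)cc1C(=O)N=C(N)N`, carries the change (tert-butyl in place of methyl on an oxygen on an aromatic ring). For the measured compounds named here, no measured step tests exactly this enlargement, but the step of a 14-fold lower number from compound 2 to compound 3 (1.14 log units; beyond the scatter) shows that what sits on this oxygen can move the read-out strongly, while the step of a 1.3-fold higher number from compound 1 to compound 3 (0.12 log units; within the scatter) shows that a small group there changes little. Because the only strong effect is seen in a 14-fold lower number from compound 2 to compound 3 (1.14 log units; beyond the scatter), the expectation for compound 4 is a modest weakening, with a step estimated at a 2.5-fold higher number from compound 3 to compound 4 (0.40 log units; beyond the scatter). The estimate for compound 4 is 40 nM, expected within 10 nM to 200 nM.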

Compound 4, half-maximal inhibitory concentration: 9.4 nM
For compound 4 the middle estimate is 4.3-fold (0.63 log units) above the measured one; the measured number lies below the stated range.
By their numbers in this assay, from the lowest: compounds 4, 1 and 3 (each within the scatter of the next); then compound 2.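

In this assay, replacing methyl with tert-butyl on this oxygen leaves the number within the scatter (a 1.7-fold lower number from compound 3 to compound 4 (0.23 log units; within the scatter)), so the group on the oxygen can grow from 1 heavy atom to 4 without a measurable loss. Tert-butoxy also stays within the scatter of bromo (a 1.3-fold lower number from compound 1 to compound 4 (0.11 log units; within the scatter)), whereas putting tert-butyl in place of the hydrogen on the oxygen gives a large step (a 23-fold lower number from compound 2 to compound 4 (1.37 log units; beyond the scatter)), which sets the hydroxy compound, compound 2, apart from compounds 1, 3 and 4. Nothing available gives a reason for this pattern.

As far as these compounds go, it remains open whether a longer chain such as n-butoxy or a ring-bearing group such as benzyloxy would fit as well on this oxygen. From the compounds shown here alone, it is also open whether an amine on this aromatic carbon would behave like the hydroxy group or like methoxy.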